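Trimming an Aryl Ester to Acetate: What to Expect

A few compounds are considered here, and "the series" means these few. Any claim that something is new, unique, unknown or untested is made for them only; others in the source may bear on it.

For the measured compounds named here, compound 1 `COc1ccc(C(=O)OC2(C(=O)Nc3ccc([N+](=O)[O-])cc3)CCCCC2)cc1` gives the lowest number measured so far in a functional assay on NFS-60 cells (Mus musculus) for inhibition, read by MTT assay, with a stated time of 72 h (on this read-out lower numbers stand for stronger inhibition and higher numbers for weaker inhibition), at 38.8 nM. Compound 2 `CCOC(=O)c1ccccc1C(=O)OC1(C(=O)Nc2ccc([N+](=O)[O-])cc2)CCCCC1` gives 488 nM in this assay, a clearly higher number. Compound 3 `CC(=O)OC1(C(=O)Nc2ccc([N+](=O)[O-])cc2)CCCCC1` differs from compound 1 by methyl in place of 4-methoxyphenyl on a carbonyl carbon. Going by the values given here, no pair of measured compounds shows this kind of change, so its size is uncertain. Because compound 1 gives 38.8 nM with the larger group in place, the step of a 7.7-fold higher number from compound 1 to compound 3 (0.89 log units; beyond the scatter) is expected to raise the number beyond the scatter. Compound 3 is estimated at 300 nM, with a likely range from 60 nM to 2000 nM.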

Compound 3, half-maximal inhibitory concentration: 517 nM
Estimate against measurement, compound 3: 1.7-fold (0.24 log units) below; measured number inside the range.
By their numbers in this assay, from the lowest: compound 1; then compounds 2 and 3 (each within the scatter of the next).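

The step of a 13-fold higher number from compound 1 to compound 3 (1.12 log units; beyond the scatter) in this assay gives the first direct measure of this change on the carbonyl carbon. It shows that the group at this position matters greatly, and that methyl does not keep the low number seen with 4-methoxyphenyl. Nothing measured here explains the rise.

Going by these compounds, it remains open whether the aromatic ring or its methoxy group accounts for the difference. Plain phenyl or cyclohexyl at this position would help separate those two possibilities.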